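This account rests on a few compounds, and the source may have more. Where it says the series, first, only, none or still open, it means among the compounds named here.

Working notes on the series.

Compound 2 `Cc1cc(N2CCCCC2)c(S(C)(=O)=O)cc1C(=O)N=C(N)N` gives 21 nM in a functional assay for inhibition of sodium/hydrogen exchanger (Oryctolagus cuniculus); a higher number here means a weaker inhibitor, a lower number a stronger inhibitor. The only other number in this assay so far comes from compound 1 `Cc1cc(-c2ccc(F)cc2)c(S(C)(=O)=O)cc1C(=O)N=C(N)N`, which gives 36 nM in this assay; the two values lie within the scatter of each other, so neither can be ranked ahead of the other on the numbers shown.

The step under study leads from compound 2 to compound 3 `Cc1cc(Nc2ccccc2)c(S(C)(=O)=O)cc1C(=O)N=C(N)N`. It is anilino in place of piperidin-1-yl on an aromatic carbon. Among the measured compounds shown here, the one measured step at the same position, a 1.7-fold lower number from compound 1 to compound 2 (0.23 log units; within the scatter), exchanged an aromatic ring for a saturated one without moving the number beyond the scatter. For the measured compounds named here, compound 3 returns an aromatic ring to that position, now joined through an amino group carrying one hydrogen-bond donor; no measured pair covers the effect of that donor. Going by the values given here, because the only comparison at this position, a 1.7-fold lower number from compound 1 to compound 2 (0.23 log units; within the scatter), stayed inside the scatter, the expectation for this assay is again a step no larger than the scatter, expected as a 1.9-fold higher number from compound 2 to compound 3 (0.28 log units; within the scatter).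

For compound 3 the estimated value in this assay is 40 nM, expected to fall between 12 nM and 130 nM.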

Compound 3, half-maximal inhibitory concentration: 21 nM
Beside the measured number, compound 3's estimate is 1.9-fold (0.28 log units) above it; low and high end bracket the measured number.
By their numbers in this assay, from the lowest: compounds 2, 3 and 1 (each within the scatter of the next).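

In this assay, the exchange of piperidin-1-yl for anilino gives no change at the digits printed from compound 2 to compound 3 (within the scatter). This shows that a hydrogen-bond donor can be present in the group at this position, with an aromatic ring joined through an amino group, without the number leaving the scatter; against the 4-fluorophenyl group the exchange gives a 1.7-fold lower number from compound 1 to compound 3 (0.23 log units; within the scatter). With all three steps among compounds 1, 2 and 3 inside the scatter, the 4-fluorophenyl, piperidin-1-yl and anilino groups cannot be ranked at this position, and no measurement to hand bears on why they read alike.

Anilino differs from piperidin-1-yl in both ring type and donor count, and from 4-fluorophenyl in both the amino link and the fluorine, so the compounds shown do not separate the contribution of any one of these features, and their agreement could reflect offsetting contributions as easily as indifference of the position. Open questions are whether phenoxy or N-methylanilino, each with a phenyl ring but no donor on the linking atom, reads the same, and whether a much smaller group such as methoxy or a bare hydrogen keeps the number inside the scatter.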